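This account rests on a few compounds, and the source may have more. Where it says the series, first, only, none or still open, it means among the compounds named here.

Two measured compounds share one core and differ in where the groups sit around it. Compound 1 `Cc1ccccc1-n1cc(-c2ccccc2NS(=O)(=O)c2c[nH]c(=O)[nH]c2=O)nn1` and compound 2 `Cc1cccc(-n2cc(-c3cccc(NS(=O)(=O)c4c[nH]c(=O)[nH]c4=O)c3)nn2)c1` were both tested in a functional assay on HepG2 cells (Homo sapiens) for antiproliferative activity, read by MTT assay, with a stated time of 24 h; a higher number here means a weaker inhibitor, a lower number a stronger inhibitor. In this assay compound 1 gives 13900 nM, and compound 2 gives 7050 nM. These two numbers lie within the usual scatter of each other, so nothing can be said about which of the pair inhibits more strongly, and compound 2 cannot be called the more active one on this evidence alone.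

Compound 3 `O=c1[nH]cc(S(=O)(=O)Nc2cccc(-c3cn(-c4cccc(Cl)c4)nn3)c2)c(=O)[nH]1` has not yet been measured in this assay. It comes from compound 2 by one change, (chloro in place of methyl on an aromatic carbon), that is, chloro in place of methyl on an aromatic carbon. Going by the values given here, no measured pair in this set shows what such a swap does here, so no step size can be taken from the data. With nothing in the set pointing either way, the step from compound 2 to compound 3 is expected to be small, a 1.2-fold lower number from compound 2 to compound 3 (0.07 log units; within the scatter), and may well stay inside the scatter. On that basis compound 3 is estimated to give 6000 nM in this assay, with a plausible range from 2500 nM to 15000 nM.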

Compound 3, half-maximal inhibitory concentration: 4200 nM
The estimate for compound 3 lay 1.4-fold (0.15 log units) above the measured number, within the range that was stated.
By their numbers in this assay, from the lowest: compounds 3, 2 and 1 (each within the scatter of the next, the first and the last beyond it).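

Swapping the 3-methylphenyl for a 3-chlorophenyl gives the first direct reading of a single change at this position, and in this assay it amounts to a 1.7-fold lower number from compound 2 to compound 3 (0.22 log units; within the scatter). At this ring carbon, meta to a large group, the assay therefore does not separate chloro from methyl, so the two groups, each counted as one heavy atom with no hydrogen-bond donors or acceptors, cannot be ranked on this evidence. No measurement offered here explains the result. What the compounds shown leave open is whether a group of a different kind at this same position, such as an amine, a carboxylic acid or a longer chain, would give a step beyond the scatter. A single pair also cannot show whether chloro in place of methyl would give a similar step on another ring carbon or on another core.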